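This account rests on a few compounds, and the source may have more. Where it says the series, first, only, none or still open, it means among the compounds named here.

Working notes on the series, read in a functional assay for inhibition, with Homo sapiens as the target; on this read-out higher numbers stand for an effect only at larger amounts of compound and lower numbers for an effect already at smaller amounts. Among the compounds with values here, compound 1 `CC(=O)Nc1ccc(C2=NNC(=O)CC2)cc1` gives 1 ug/mL, the lowest number so far. Compound 2 `CC1CC(c2ccc(N)cc2)=NNC1=O` gives 43.8 ug/mL, higher than compound 1 by a margin well beyond the scatter. Compound 3 `Nc1cccc(C2=NNC(=O)CC2)c1` returns only a limit, > 46.4 ug/mL.

Compound 4 `CC(C)(CCl)C(=O)Nc1ccc(C2=NNC(=O)CC2)cc1` is still unmeasured. It differs from compound 1 by 1-(chloromethyl)-1-methylethyl in place of methyl on a carbonyl carbon. The same difference reads acetyl to (1-(chloromethyl)-1-methylethyl)carbonyl. Within the data shown here, no measured pair tests this change, so the forecast in this assay carries wide margins. Compound 1 at 1 ug/mL is the reference point, and a modest move towards a lower number is expected, though a move the other way is not excluded. The expected step is a 2.0-fold lower number from compound 1 to compound 4 (0.30 log units; within the scatter). For compound 4 the estimated value is 0.5 ug/mL, within an expected range of 0.06 ug/mL to 5 ug/mL.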

Compound 4, half-maximal effective concentration: 11.4 ug/mL
Compound 4: middle estimate off by 23-fold (1.36 log units), on the low side; measured number above the stated range.
By their numbers in this assay, from the lowest: compound 1; then compound 4; then compound 2. At a limit, above all of these: compound 3.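

In this assay, 1-(chloromethyl)-1-methylethyl in place of methyl on a carbonyl carbon brings an 11-fold higher number from compound 1 to compound 4 (1.06 log units; beyond the scatter). Within the data shown here, this is the first step read at this place, and it shows that the number depends strongly on the group carried there, while compound 4 still gives a measured number rather than a limit. Nothing measured in the series accounts for the size of this step.

Still open, from the compounds shown here alone, is whether the step follows from the chlorine or from the branched chain; a tert-butyl group on the same carbonyl carbon would separate the two. Also open, going by these compounds, is whether any group at this place, such as ethyl, cyclopropyl or a chain ending in an amine, gives a lower number than compound 1.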